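The source may report more compounds than this note shows. Statements on the series, on what has been measured and on what is new or still open speak of the compounds shown alone.

Measured in an assay on A10 cells for antagonist activity at Endothelin-1 receptor (Rattus norvegicus); on this read-out higher numbers stand for weaker inhibition and lower numbers for stronger inhibition:

compound 1 `COc1ccccc1C(Oc1cc(OCc2ccsc2)ccc1C#N)C(=O)O` – 529 nM
compound 2 `N#Cc1ccc(OCc2ccsc2)cc1OC(C(=O)O)c1ccco1` – 2400 nM
compound 3 `Cc1ccccc1C(Oc1cc(OCc2ccccc2)ccc1C#N)C(=O)O` – 49 nM

Compound 3 gives the lowest number of the three; compound 1 is nearest to it and compound 2 furthest, and both of those gaps exceed the usual scatter.

Compound 4 `Cc1ccccc1C(Oc1cc(OCc2ccc3c(c2)OCCO3)ccc1C#N)C(=O)O` is not yet measured. It differs from compound 3 in one place: 2,3-dihydro-1,4-benzodioxin-6-yl in place of phenyl on a saturated chain carbon bound to an oxygen on an aromatic ring.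

For the measured compounds named here, the only step between measured compounds that differ in one place is a 4.5-fold higher number from compound 1 to compound 2 (0.66 log units; beyond the scatter), and it sits on a saturated chain carbon bound to a carbonyl carbon and an oxygen on an aromatic ring, not on the carbon that carries the change from compound 3 to compound 4. Going by the values given here, no measured pair differs only in the group attached to the saturated chain carbon bound to an oxygen on an aromatic ring, so the size of this step has no direct precedent. With nothing to point in either direction, the expectation for compound 4 in this assay is a step of about a 1.2-fold higher number from compound 3 to compound 4 (0.09 log units; within the scatter), within the scatter. Compound 4 is therefore estimated at 60 nM, with a range of 20 nM to 200 nM.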

Compound 4, half-maximal inhibitory concentration: 1500 nM
Beside the measured number, compound 4's estimate is 25-fold (1.40 log units) below it; measured number outside the range, above it.
By their numbers in this assay, from the lowest: compound 3; then compound 1; then compounds 4 and 2 (each within the scatter of the next).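

In this assay, for the compounds shown here, the group on the saturated chain carbon bound to an oxygen on an aromatic ring proves decisive: 2,3-dihydro-1,4-benzodioxin-6-yl in place of phenyl gives a 31-fold higher number from compound 3 to compound 4 (1.49 log units; beyond the scatter), the first direct reading at this position. So the position does not accept every group that keeps the six-membered aromatic ring of carbon only, since the entering group also brings a six-membered non-aromatic ring with 2 hetero atoms and 2 hydrogen-bond acceptors. Nothing available explains the loss.

This single pair cannot separate the effect of the added ring from that of its two oxygens. Open too, on these data alone, is how phenyl compares at this position with a pyridine ring, or with a phenyl carrying a single fluorine or methoxy group.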